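This account rests on a few compounds, and the source may have more. Where it says the series, first, only, none or still open, it means among the compounds named here.

Working notes on the series. In a functional assay on MCF7 cells (Homo sapiens) for cytotoxicity, read by MTT assay, with a stated time of 48 h (on this read-out higher numbers stand for weaker inhibition and lower numbers for stronger inhibition), compound 1 `COc1cc(-c2nnc3n2NC(c2cccs2)C(C(=O)c2ccccc2)S3)cc(OC)c1OC` reaches only the limit of the assay, > 100000 nM. Compound 2 `COc1cc(-c2nnc3n2NC(c2ccco2)C(C(=O)c2ccc(F)c(F)c2)S3)cc(OC)c1OC` gives 73200 nM in this assay. Compound 3 `COc1cc(-c2nnc3n2NC(c2ccco2)C(C(=O)c2ccco2)S3)cc(OC)c1OC` likewise ends at the limit in this assay, > 100000 nM, so only a bound is known for it. Among the compounds with values here, the one measured step that reaches compound 3, an at least 1.3-fold higher number from compound 2 to compound 3 (0.13 log units; that floor lies within the scatter), has a floor within the scatter and ends at the limit noted in the limit of > 100000 nM in this assay, at which 2 of the 3 values shown sit.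

Compound 4 `COc1ccc(C(=O)C2Sc3nnc(-c4cc(OC)c(OC)c(OC)c4)n3NC2c2ccco2)cc1` differs from compound 3 by 4-methoxyphenyl in place of furan-2-yl on a carbonyl carbon. Within the data shown here, the only measured step on the carbonyl substituent is the one from compound 2 to compound 3; read in reverse, an aromatic group entering on the carbonyl carbon would point at most toward a slightly lower number, and that step is not resolved from the scatter. Compound 1, which also carries an aromatic group on the carbonyl carbon, stands at the limit as well. Compound 4 is therefore expected to show a step of a number no higher from compound 3 to compound 4 (the limit leaves the size open), that is, none beyond the scatter. The estimate for compound 4 in this assay is 100000 nM, with a range from 45000 nM to 200000 nM, most likely reported as a limit.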

Compound 4, half-maximal inhibitory concentration: > 100000 nM
Compound 4: no number, only a limit; the forecaster's own chance of this, stated with the estimate: 65%; the middle value sits exactly at the limit.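

Working notes, continued. With 4-methoxyphenyl on the carbonyl carbon, a six-membered aromatic ring of carbon only now also ends at the limit in this assay, as furan-2-yl did, so an aromatic group at this place does not by itself give a measured number: the limit of > 100000 nM in this assay, at which 3 of the 4 values shown sit. Of the new steps, only one can be read, an at least 1.3-fold higher number from compound 2 to compound 4 (0.13 log units; that floor lies within the scatter), so 3,4-difluorophenyl and 4-methoxyphenyl are not separated at this place. The step between the two limits cannot be read.

From the compounds shown here alone, it remains open whether any group on this carbonyl carbon gives a number clearly clear of the limit, for instance an aliphatic amine or a carboxylic acid in place of 4-methoxyphenyl. Compounds 2, 3 and 4 share the same core, so they also leave open how changes elsewhere would read.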